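Aryl urea variation on the shared core, para-nitro analogue

A few compounds are considered here, and "the series" means these few. Any claim that something is new, unique, unknown or untested is made for them only; others in the source may bear on it.

Compound 1 `Cc1ccc(NC(=O)Nc2cccc(CNc3ncnc4ccccc34)c2)cc1` and compound 2 `O=C(Nc1cccc(CNc2ncnc3ccccc23)c1)Nc1ccccc1F` share the core and differ only in the aryl urea terminus. In a functional assay on A549 cells (Homo sapiens) for antiproliferative activity, read by MTT assay (a lower number here means a stronger inhibitor, a higher number a weaker inhibitor), compound 1 gives 24900 nM, and compound 2 gives 26100 nM; the step of a 1.0-fold higher number from compound 1 to compound 2 (0.02 log units; within the scatter) places the two within the scatter of each other, so compound 2 stands level with compound 1 on the numbers to hand. Compound 3 `O=C(Nc1ccc([N+](=O)[O-])cc1)Nc1cccc(CNc2ncnc3ccccc23)c1` continues the same variation: 4-nitrophenyl in place of 2-fluorophenyl on an amide-type nitrogen. Among the compounds with values here, only the one measured step bears on this change, and it showed no movement, so no shift beyond the scatter is expected, a 1.0-fold lower number from compound 2 to compound 3 (0.02 log units; within the scatter). Compound 3 is estimated at 25000 nM, within 9000 nM to 70000 nM.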

Compound 3, half-maximal inhibitory concentration: > 50000 nM
Compound 3 gave a limit, no number; the forecaster's own chance of this, stated with the estimate: 10%; middle value at least 2.0-fold (0.30 log units) from the limit.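

In this assay compound 3 gives a limit, not a number: the limit of > 50000 nM in this assay, at which 1 of the 3 values shown sits. 4-Nitrophenyl in place of 2-fluorophenyl gives an at least 1.9-fold higher number from compound 2 to compound 3 (0.28 log units; that floor lies within the scatter), and nitro in place of methyl gives an at least 2.0-fold higher number from compound 1 to compound 3 (0.30 log units; that floor lies within the scatter). Both floors lie within the scatter, so the level reading of the earlier pair can be neither extended to this change nor set aside, and no true step size can be given.

Open, going by these compounds, is how an amine or a carboxylic acid on this aryl ring would read in this assay. Also open, on these data alone, is whether a numerical value could be obtained for a nitro-bearing urea.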